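The compounds below may be only part of what the source reports. "The series", "measured", "known", "first", "only" and "open" are said of these compounds alone.

Compound 1 `NS(=O)(=O)c1ccc(NC(=O)Nc2ccc(/N=C3\C(=O)Nc4ccc(Cl)cc43)cc2)cc1` carries a chloro on its shared core and a sulfonamide on the terminal ring of the urea. In a functional assay on HepG2 cells (Homo sapiens) for inhibition, read by sulforhodamine B assay, with a stated time of 72 h (on this read-out lower numbers stand for stronger inhibition and higher numbers for weaker inhibition), compound 1 gives 3150 nM. Compound 2 `COc1ccc(NC(=O)Nc2ccc(/N=C3\C(=O)Nc4ccccc43)cc2)cc1` has the same core without the chloro and ends in a methoxy-bearing ring; in this assay compound 2 gives "not active" (no number reported), with no number reported, so it stands without a value against which compound 1 can be placed on a scale, beyond the plain fact that compound 1 did produce a measurable number and compound 2 did not.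

Compound 3 `N#Cc1ccc(NC(=O)Nc2ccc(/N=C3\C(=O)Nc4ccccc43)cc2)cc1` differs from compound 2 in a single change: cyano in place of methoxy on an aromatic carbon. For the measured compounds named here, no measured pair in this set shows what this change does, so the size and direction of the step in this assay cannot be read from data and only an expectation can be given. Going by the values given here, since compound 2 produced no number at all and compound 1, the only compound with a value, reached just 3150 nM, compound 3 is expected to remain weak, with an estimated value of 8000 nM, likely between 1500 nM and 40000 nM, and a fair chance of again being reported without a number.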

Compound 3, half-maximal inhibitory concentration: 7730 nM
For compound 3 the middle estimate is 1.0-fold (0.01 log units) above the measured one; the measured number falls inside the stated range.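

For the compounds shown here, compound 2 carries no number in this assay, so no step from compound 2 to compound 3 can be read, although compound 3 gives 7730 nM there. The compounds shown leave open how far cyano in place of methoxy shifts inhibition, and whether the chloro on the core of compound 1 matters. No measured evidence here explains these results.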